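One Added Methoxy at the Limit of a Cell Assay

The source may hold more compounds than are shown below. What is called first, only, known or untested is meant among the compounds shown, and "the series" means these compounds.

Compound 1 (`COc1ccc(-c2nc3cc(C(C)=O)ccc3[nH]2)c(OC)c1`): > 100000 nM, a limit
Compound 2 (`COc1ccc(-c2nc3cc(/C(C)=N/NC(N)=S)ccc3[nH]2)cc1`): > 100000 nM, a limit

The measure here is an ADME assay on Vero cells (Chlorocebus sabaeus) for cytotoxicity, read by MTT assay, with a stated time of 96 h; a lower number here means that less compound is tolerated, a higher number that more compound is tolerated. In this assay compound 2 stands at > 100000 nM, which is a limit of the assay and not a number. Among the compounds with values here, the only guide on the measured compounds is the limit of > 100000 nM in this assay, at which 2 of the 2 values shown sit. Within the data shown here, neither value is a number, so no measured step exists to go by.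

Compound 3 (`COc1ccc(-c2nc3cc(/C(C)=N/NC(N)=S)ccc3[nH]2)c(OC)c1`) differs from compound 2 by a methoxy in place of hydrogen on an aromatic carbon, ortho to a large group and meta to a methoxy group: methoxy in place of hydrogen on an aromatic carbon.

With nothing measured to set a size or a direction, no change beyond the scatter is expected. The expectation is written as a number no higher from compound 2 to compound 3 (the limit leaves the size open). It rests on compound 2 and its > 100000 nM, again only a limit. Compound 3 may well be reported as a limit too. For compound 3 the estimated value is 100000 nM, with an expected range from 40000 nM to 200000 nM.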

Compound 3, half-maximal cytotoxic concentration: > 100000 nM
Compound 3: a limit, no number (the forecaster's own chance of this, stated with the estimate: 70%); the middle value lies on the limit itself.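

In this assay compound 3 gives > 100000 nM as a limit of the assay, not a number. Within the data shown here, compound 1 and compound 2 also stand at limits, so no step to compound 3 can be read. The compounds shown leave open whether methoxy in place of hydrogen on an aromatic carbon changes the read-out of this assay at all, and at what concentration any of them would harm the cells.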